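Changing the methylcarbamoyl group on one ring carbon

This account rests on a few compounds, and the source may have more. Where it says the series, first, only, none or still open, it means among the compounds named here.

Measured in a functional assay (aorta) with Rattus norvegicus as the target; on this read-out lower numbers stand for an effect already at smaller amounts and higher numbers for an effect only at larger amounts of compound:
- compound 1 `C/N=C(/S)C1=CC(C)(C)Oc2ccc(C#N)cc21`: 24.6 nM
- compound 2 `CNC(=O)C1=CC(C)(C)Oc2ccc(C#N)cc21`: 263 nM

Of these two, compound 2 has the higher number, so it needs larger amounts to show its effect. The next compound, compound 3 `C/N=C(/NC#N)C1=CC(C)(C)Oc2ccc(C#N)cc21`, keeps the shared core and changes one group: a group of 6 heavy atoms (3 carbon, 3 nitrogen; no ring) in place of a group of 4 heavy atoms (2 carbon, 1 nitrogen, 1 oxygen; no ring), on a double-bonded ring carbon. The methylcarbamoyl group leaves, and a group without a common name enters on the same double-bonded ring carbon.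

Going by the values given here, only one measured step bears on this change: an 11-fold higher number from compound 1 to compound 2 (1.03 log units; beyond the scatter). This large step took place at that same ring carbon, so changes there can clearly move the number. Compound 3 also lacks the oxygen of compound 2, as does compound 1 at 24.6 nM. However, its new group differs from both groups measured so far, so this comparison is only a rough guide. In this assay, a moderate move toward lower numbers is therefore expected: a 4.4-fold lower number from compound 2 to compound 3 (0.64 log units; beyond the scatter). For compound 3 the estimated value is 60 nM, with an expected range from 12 nM to 300 nM. The range is wide, as a single measured step is all the evidence available.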

Compound 3, half-maximal effective concentration: 339 nM
Compound 3: middle estimate off by 5.7-fold (0.75 log units), on the low side; measured number outside the range, above it.
By their numbers in this assay, from the lowest: compound 1; then compounds 2 and 3 (each within the scatter of the next).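

In this assay, the group of compound 3 and the methylcarbamoyl group cannot be told apart at this double-bonded ring carbon (a 1.3-fold higher number from compound 2 to compound 3 (0.11 log units; within the scatter)), even though the two groups differ in their atoms and in their count of hydrogen-bond acceptors. The sharper comparison is with compound 1, which shares with compound 3 the carbon with a double bond to nitrogen, the two differing only in cyanoamino in place of sulfanyl (a 14-fold higher number from compound 1 to compound 3 (1.14 log units; beyond the scatter)); lacking the oxygen of compound 2 is therefore not enough on its own to give a low number, and among these three compounds only compound 1, with its sulfanyl group, stands apart. Nothing measured here accounts for this difference.

On these data alone, it remains open whether the low number of compound 1 depends on sulfur itself, which a methoxy group or a plain amine in place of sulfanyl on that same carbon would help to show. The compounds shown also leave open how much room the nitrogen substituent allows, since an ethyl group or a longer chain in place of methyl there has no value here.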